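Nitro to carboxy on a growth inhibitor

The source may report more compounds than this note shows. Statements on the series, on what has been measured and on what is new or still open speak of the compounds shown alone.

In a functional assay on HeLa cells (Homo sapiens) for cytotoxicity, read by sulforhodamine B assay, with a stated time of 48 h (a higher number here means a weaker inhibitor of growth, a lower number a stronger inhibitor of growth), compound 1 `Cc1nn(-c2ccccc2)c(Oc2ccc(-c3nc4cc([N+](=O)[O-])ccc4[nH]3)cc2)c1/C=N/NC(N)=S` gives 6600 nM. Compound 2 `CC(=O)N/N=C/c1c(C)nn(-c2ccccc2)c1Oc1ccc(-c2nc3cc([N+](=O)[O-])ccc3[nH]2)cc1` gives 7130 nM, so a 1.1-fold higher number from compound 1 to compound 2 (0.03 log units; within the scatter) leaves the two together, within the usual scatter. Compound 3 `Cc1nn(-c2ccccc2)c(Oc2ccc(-c3nc4cc(C(=O)O)ccc4[nH]3)cc2)c1/C=N/NC(N)=S` keeps the core of compound 1 and alters a single group: carboxy in place of nitro on an aromatic carbon. Going by the values given here, the one measured step concerns a group on an amine nitrogen, not this aromatic carbon, so it offers no direct guide to the new change. Among the compounds with values here, no measured pair covers this swap, which leaves its size open. A modest move towards a higher number, meaning weaker growth inhibition, is the expected outcome, estimated as a 1.5-fold higher number from compound 1 to compound 3 (0.18 log units; within the scatter) with wide margins. In this assay the estimated value for compound 3 is 10000 nM, with an expected range from 3500 nM to 35000 nM.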

Compound 3, concentration for 50% growth inhibition: 22700 nM
Estimate against measurement, compound 3: 2.3-fold (0.36 log units) below; measured number inside the range.
By their numbers in this assay, from the lowest: compounds 1 and 2 (each within the scatter of the next); then compound 3.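

In this assay, the aromatic carbon carrying the nitro group proves sensitive to change: carboxy in place of nitro gives a 3.4-fold higher number from compound 1 to compound 3 (0.54 log units; beyond the scatter), meaning weaker growth inhibition, whereas the earlier change on the amine nitrogen gave a 1.1-fold higher number from compound 1 to compound 2 (0.03 log units; within the scatter). The two groups match in heavy-atom count, yet carboxy has a hydrogen-bond donor that nitro lacks, so this pair shows that the position can tell apart two groups of equal heavy-atom count. Nothing measured here explains the step.

With only one replacement shown at this carbon, it remains open whether the weakening is specific to carboxy or would follow any loss of nitro. An amine, a methyl ester or a plain hydrogen here would help separate those possibilities, and the same swap on compound 2 would show whether the step carries over.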